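The source may report more compounds than this note shows. Statements on the series, on what has been measured and on what is new or still open speak of the compounds shown alone.

Compound 1, `C[C@H](NC(=O)c1c(C(F)(F)F)nnn1Cc1ccc(C(F)(F)F)cc1)c1ccc(C(=O)O)cc1`, gives 225 nM in a functional assay on CHO cells for antagonist activity at prostaglandin E2 receptor EP4 subtype (Homo sapiens), read by calcium flux, with a stated time of 15 min; a higher number here means a weaker inhibitor, a lower number a stronger inhibitor. Compound 2, `Cc1nnn(Cc2ccc(C(F)(F)F)cc2)c1C(=O)N[C@@H](C)c1ccc(C(=O)O)cc1`, reaches only the assay limit of > 10000 nM in this assay. Compound 3, `C[C@H](NC(=O)c1c(-c2ccc(F)cc2)nnn1Cc1ccc(C(F)(F)F)cc1)c1ccc(C(=O)O)cc1`, gives 57.9 nM in this assay.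

Compound 3 stands lowest of the numbers shown, with compound 1 nearest: a 3.9-fold lower number from compound 1 to compound 3 (0.59 log units; beyond the scatter). Compound 4, `C=CCc1nnn(Cc2ccc(C(F)(F)F)cc2)c1C(=O)N[C@@H](C)c1ccc(C(=O)O)cc1`, differs from compound 3 by allyl in place of 4-fluorophenyl on an aromatic carbon. Within the data shown here, the steps that bear on this are an at least 170-fold lower number from compound 2 to compound 3 (2.23 log units; beyond the scatter) and an at least 44-fold higher number from compound 1 to compound 2 (1.64 log units; beyond the scatter), where the ringless methyl group sat at the assay limit (the limit of > 10000 nM in this assay, at which 1 of the 3 values shown sits). Allyl, also ringless, is expected to behave more like methyl than like 4-fluorophenyl. Compound 4 is therefore expected to give 3000 nM in this assay, within 400 nM to 20000 nM. The expected step is a 52-fold higher number from compound 3 to compound 4 (1.71 log units; beyond the scatter).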

Compound 4, half-maximal inhibitory concentration: > 1000 nM
Compound 4 ended at the assay's limit (the forecaster's own chance of this, stated with the estimate: 35%); the middle value does not contradict the limit.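

Compound 4 reaches only a limit of the assay in this assay (> 1000 nM). Allyl, a second ringless carbon group after methyl, falls well short of 4-fluorophenyl (an at least 17-fold higher number from compound 3 to compound 4 (1.23 log units; beyond the scatter)) and also of trifluoromethyl (an at least 4.4-fold higher number from compound 1 to compound 4 (0.64 log units; beyond the scatter)). Not every ringless group fails, however, as compound 1 carries trifluoromethyl; the step between compound 2 and compound 4 cannot be read, both values being limits. Going by these compounds, whether a plain phenyl or a cyclopropyl group at this place would match 4-fluorophenyl stays open.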